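A few compounds are considered here, and "the series" means these few. Any claim that something is new, unique, unknown or untested is made for them only; others in the source may bear on it.

Measured so far in a functional assay on MDA-MB-231 cells (Homo sapiens) for cytotoxicity, read by MTT assay, with a stated time of 48 h; a higher number here means a weaker inhibitor, a lower number a stronger inhibitor:
Compound 1 `O=C(c1cc(Oc2cccc(NC(=S)Nc3ccc(F)c(F)c3)c2)ccn1)N1CCCC1` gives > 100000 nM, a limit of the assay.
Compound 2 `CC(C)NC(=O)c1cc(Oc2cccc(NC(=S)Nc3ccc(OC(F)(F)F)cc3)c2)ccn1` gives > 100000 nM, a limit of the assay.
Compound 3 `O=C(NCc1ccccc1)c1cc(Oc2cccc(NC(=S)Nc3ccc(OC(F)(F)F)cc3)c2)ccn1` gives > 100000 nM, a limit of the assay.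

Compound 3 stands only at a limit, and the two other values shown are limits as well, so no order among the three can be read. Among the compounds with values here, the single one-point step within the measured set, a step that the two limits leave unreadable from compound 2 to compound 3, is left unreadable by the two limits. Compound 4 `O=C(c1cc(Oc2cccc(NC(=S)Nc3ccc(OC(F)(F)F)cc3)c2)ccn1)N1CCCC1` differs from compound 3 by pyrrolidin-1-yl in place of benzylamino on a carbonyl carbon. Within the data shown here, the entering pyrrolidin-1-yl group is the one compound 1 carries on the same carbonyl carbon, and compound 1 also sits at the limit (the limit of > 100000 nM in this assay, at which 3 of the 3 values shown sit). The data therefore give no size or direction to build on. The expected step is a step that the limit leaves unreadable from compound 3 to compound 4. Compound 4 is estimated at 150000 nM, with a range from 40000 nM to 600000 nM, most likely again only a limit.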

Compound 4, half-maximal inhibitory concentration: 37800 nM
The estimate for compound 4 lay 4.0-fold (0.60 log units) above the measured number; the whole stated range lies above it.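

In this assay compound 4 is the only compound shown with a value off the limit, and the carbonyl carbon now responds to change: pyrrolidin-1-yl in place of benzylamino gives an at least 2.6-fold lower number from compound 3 to compound 4 (0.42 log units; beyond the scatter) and pyrrolidin-1-yl in place of isopropylamino gives an at least 2.6-fold lower number from compound 2 to compound 4 (0.42 log units; beyond the scatter). Pyrrolidin-1-yl alone is not enough, as compound 1 carries it too; 4-(trifluoromethoxy)phenyl in place of 3,4-difluorophenyl gives an at least 2.6-fold lower number from compound 1 to compound 4 (0.42 log units; beyond the scatter). Each step is only a bound, set by the limit on the other compound: the limit of > 100000 nM in this assay, at which 3 of the 4 values shown sit.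

On these data alone, whether other cyclic amines on the carbonyl carbon, such as piperidine or morpholine, go further stays open. So does the effect of a carboxylic acid there.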